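The source may hold more compounds than are shown below. What is called first, only, known or untested is meant among the compounds shown, and "the series" means these compounds.

In a functional assay on RKE cells for antagonist activity at Vasoactive intestinal polypeptide receptor 1 (Rattus norvegicus), read by HTRF and cAMP accumulation, with stated times of 10 min and 30 min (on this read-out higher numbers stand for weaker inhibition and lower numbers for stronger inhibition), compound 1 `CCC(=O)Nc1sc2c(c1C#N)CCCC2` gives 12000 nM. Compound 3 `Cc1ccc(-c2cc(C(C)(C)C)cc(C(C)C)c2CO)cc1` gives 300 nM in this assay. Compound 2 `CC(C)c1cc(C(C)(C)C)cc(-c2cccc(C(F)(F)F)c2)c1CO` gives only > 50000 nM in this assay, which is a limit of the measurement and not a number, and it stands at the limit of > 50000 nM in this assay, at which 1 of the 3 values shown sits. Compound 4 `COc1cccc(-c2cc(C(C)(C)C)cc(C(C)C)c2CO)c1` has not been measured; it differs from compound 2 by methoxy in place of trifluoromethyl on an aromatic carbon. For the measured compounds named here, no measured pair shows this exact change, so the size of the step has no direct precedent. The step of an at least 10-fold lower number from compound 2 to compound 4 (1.00 log units; beyond the scatter) is expected to run toward stronger inhibition, although from a start that is itself only a limit its size remains uncertain. Compound 4 is therefore estimated at 5000 nM in this assay, with a range from 500 nM to 50000 nM.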

Compound 4, half-maximal inhibitory concentration: 200 nM
Compound 4: middle estimate off by 25-fold (1.40 log units), on the high side, outside the stated range (below it).
By their numbers in this assay, from the lowest: compounds 4 and 3 (each within the scatter of the next); then compound 1. At a limit, above all of these: compound 2.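

This aromatic carbon, meta to a large group, proves highly sensitive: methoxy in place of trifluoromethyl gives an at least 250-fold lower number from compound 2 to compound 4 (2.39 log units; beyond the scatter). For the compounds shown here, the earlier compounds offered no pair differing in one place, so this is the first direct sign that a single group here can strongly change inhibition. Compound 2 has only a limit, so the full size of the step stays unknown: the limit of > 50000 nM in this assay, at which 1 of the 4 values shown sits.

Going by these compounds, whether methoxy itself helps, or trifluoromethyl simply hinders, remains open. No compound shown carries a plain hydrogen, a hydroxyl group or an amine at this place.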